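Swapping the Ring on the Hydrazone Carbon

This account rests on a few compounds, and the source may have more. Where it says the series, first, only, none or still open, it means among the compounds named here.

Measured so far in a functional assay on SGC-7901 cells (Homo sapiens) for cytotoxicity, read by MTT assay, with a stated time of 38 h; on this read-out lower numbers stand for stronger inhibition and higher numbers for weaker inhibition:
- compound 1 `COc1cc(OC)c2c(=O)c(OCC(=O)N/N=C/c3ccccc3F)c(-c3cc(OC)c(OC)c(OC)c3)oc2c1` gives 7720 nM
- compound 2 `COc1cc(OC)c2c(=O)c(OCC(=O)N/N=C/c3ccc[nH]3)c(-c3cc(OC)c(OC)c(OC)c3)oc2c1` gives 8730 nM

These two compounds share the same core and differ only in the ring on a carbon with a double bond to nitrogen. Compound 2 (8730 nM) stands level with compound 1 (7720 nM), as the two numbers lie within the usual scatter of repeat measurements.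

The next compound, compound 3 `COc1cc(OC)c2c(=O)c(OCC(=O)N/N=C/c3ccccn3)c(-c3cc(OC)c(OC)c(OC)c3)oc2c1`, carries pyridin-2-yl in place of 1H-pyrrol-2-yl at that carbon, a change counted as pyridin-2-yl in place of 1H-pyrrol-2-yl on a carbon with a double bond to nitrogen and made on a carbon with a double bond to nitrogen.

Going by the values given here, only one measured step bears on this change: the ring exchange at the same carbon, a 1.1-fold higher number from compound 1 to compound 2 (0.05 log units; within the scatter), which stayed within the scatter. Among the compounds with values here, no measured compound yet carries pyridin-2-yl, so this single step is thin evidence. In this assay the expected step is therefore none beyond the scatter, namely a 1.1-fold lower number from compound 2 to compound 3 (0.04 log units; within the scatter) and no more. The estimate for compound 3 is 8000 nM, with an expected range from 3500 nM to 18000 nM.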

Compound 3, half-maximal inhibitory concentration: 16200 nM
Compound 3: the middle estimate sits 2.0-fold (0.31 log units) below what was measured; measured number inside the range.
By their numbers in this assay, from the lowest: compounds 1, 2 and 3 (each within the scatter of the next, the first and the last beyond it).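

In this assay this carbon with a double bond to nitrogen gives its first step beyond the scatter, since pyridin-2-yl in place of 2-fluorophenyl brings a 2.1-fold higher number from compound 1 to compound 3 (0.32 log units; beyond the scatter) and so a modest weakening. Against 1H-pyrrol-2-yl the same ring shows a 1.9-fold higher number from compound 2 to compound 3 (0.27 log units; within the scatter) and stays within the scatter, so compound 2 and compound 3 cannot be told apart here, even though a five-membered aromatic ring with a hydrogen-bond donor gives way to a six-membered one with a hydrogen-bond acceptor. No measurement at hand explains why pyridin-2-yl separates from 2-fluorophenyl and not from 1H-pyrrol-2-yl.

On these data alone, all three compounds carry an aromatic ring at this carbon, so it remains open whether a ring is needed there at all, a question that a small methyl group or a longer alkyl chain could address. As far as these compounds go, it also remains open how far the ring itself can be changed, for instance a plain phenyl without fluorine, or a phenyl ring carrying an amine or a carboxylic acid.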